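Aryl amine variation on the shared urea core

A few compounds are considered here, and "the series" means these few. Any claim that something is new, unique, unknown or untested is made for them only; others in the source may bear on it.

Measured so far:
compound 1 `Cc1ccc(Nc2cc(NC(=O)Nc3c(Cl)cccc3Cl)ncn2)cc1F` — 40.7%
compound 2 `COc1ccc(Nc2cc(NC(=O)Nc3c(Cl)cccc3Cl)ncn2)cc1C` — 50%

In a functional assay on NCI-H226 cells (Homo sapiens) for inhibition, read by MTT assay, with a stated time of 48 h, tested at 10 uM (a higher number here means more inhibition at the concentration tested (going by the name of the read-out), a lower number less inhibition), compound 1 gives 40.7% and compound 2 gives 50%. Compound 2 holds the higher of the two numbers shown, but the step of a number 9.3 percentage points higher from compound 1 to compound 2 (within the scatter) lies within the scatter, so no order between compound 1 and compound 2 can be read from it.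

Compound 3 `O=C(Nc1cc(Nc2ccc(F)c(Cl)c2)ncn1)Nc1c(Cl)cccc1Cl` is not yet measured. Relative to compound 2 the change is 3-chloro-4-fluorophenyl in place of 4-methoxy-3-methylphenyl on a nitrogen on an aromatic ring. Among the measured compounds shown here, the only measured step that bears on it is the one from compound 1 to compound 2, which also exchanges the aryl group on the same nitrogen and came out as a number 9.3 percentage points higher from compound 1 to compound 2 (within the scatter), a change within the scatter. On that basis a third aryl group at this position is expected to give a step of about a number 5 percentage points lower from compound 2 to compound 3 (within the scatter), that is, none beyond the scatter. Compound 3 is therefore estimated at 45%, with a range from 25% to 65%.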

Compound 3, a percentage reported as inhibition, at one concentration (the size of the read-out at that concentration, not a potency): 47.3%
Beside the measured number, compound 3's estimate is 2.3 percentage points below it; the range from low to high includes it.
By their numbers in this assay, from the lowest: compounds 1, 3 and 2 (each within the scatter of the next).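

In this assay, 3-chloro-4-fluorophenyl gives a number 2.7 percentage points lower from compound 2 to compound 3 (within the scatter) and a number 6.6 percentage points higher from compound 1 to compound 3 (within the scatter), so a third aryl group on this nitrogen still produces no step beyond the scatter. The change from 4-methoxy-3-methylphenyl, with 1 hydrogen-bond acceptor, to 3-chloro-4-fluorophenyl, with 0 hydrogen-bond acceptors, therefore has no readable effect on the number at this single concentration. No supporting evidence bears on this result.

Going by these compounds, whether any group on this nitrogen can move the number beyond the scatter remains open, for instance a phenyl ring carrying a carboxylic acid or an amine, or a longer chain in place of the aryl ring. All three compounds also share the rest of the core, so what a change elsewhere on the urea would do is equally unknown.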